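Swapping bromine for chlorine on two different cores

This account rests on a few compounds, and the source may have more. Where it says the series, first, only, none or still open, it means among the compounds named here.

Compound 1 `CN(C)c1ccc(C2CC(c3ccccc3)=NN2C2=NC(=O)/C(=C3\C(=O)Nc4ccc(Br)cc43)S2)cc1` and compound 2 `CN(C)c1ccc(C2CC(c3ccccc3)=NN2C2=NC(=O)/C(=C3\C(=O)Nc4ccc(Cl)cc43)S2)cc1` share one core, and compound 3 `COc1ccc(-c2cc(-c3ccc(Cl)cc3)n(C3C(=O)Nc4ccc(Br)cc43)n2)cc1` and compound 4 `COc1ccc(-c2cc(-c3ccc(Cl)cc3)n(C3C(=O)Nc4ccc(Cl)cc43)n2)cc1` share another. The difference between the two cores is not broken down here. In a functional assay on cells (Cancer cell lines, Homo sapiens) for cytotoxicity, read by sulforhodamine B assay, with a stated time of 48 h (on this read-out lower numbers stand for stronger inhibition of growth and higher numbers for weaker inhibition of growth), compound 1 gives 450 nM and compound 2 gives 430 nM. The change between them is chloro in place of bromo on an aromatic carbon and it gave a 1.0-fold lower number from compound 1 to compound 2 (0.02 log units; within the scatter). Compound 3 gives 32300 nM in this assay, a far higher number than either compound on the first core. The change from compound 3 to compound 4 is chloro in place of bromo on an aromatic carbon, and since the place of the change is described in the same words as before, it is the same change made on a different core. Going by the values given here, for compound 4 the step expected in this assay is a 1.0-fold lower number from compound 3 to compound 4 (0.00 log units; within the scatter), resting on the single earlier example, where the step from compound 1 to compound 2 stayed within the usual scatter, although one example on another core is thin ground. Compound 4 is therefore estimated at 32000 nM, between 14000 nM and 70000 nM.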

Compound 4, concentration for total growth inhibition: 13200 nM
For compound 4 the middle estimate is 2.4-fold (0.38 log units) above the measured one, and the stated range ends above it.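

In this assay, chloro in place of bromo on the core of compound 3 gave a 2.4-fold lower number from compound 3 to compound 4 (0.39 log units; beyond the scatter), a modest step, whereas the same change on the core of compound 1 stayed within the scatter. Set side by side, the two steps cannot be told apart: the same change on two cores in this assay, a 1.0-fold lower number (0.02 log units; within the scatter) from compound 1 to compound 2 and a 2.4-fold lower number (0.39 log units; beyond the scatter) from compound 3 to compound 4, 2.3-fold (0.37 log units) apart, within the scatter of two such steps. These two pairs therefore fit the idea that this swap carries over between the two cores, but they do not show that the two cores respond in exactly the same way, and two pairs cannot predict the result on any further core.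

The compounds shown carry only bromo or chloro at this place on the aromatic ring, so it remains open how a plain hydrogen, a fluoro group, an amine or a carboxylic acid on the same carbon would behave in this assay. Going by these compounds, it also remains open whether such replacements would give similar steps on both cores.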